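A few compounds are considered here, and "the series" means these few. Any claim that something is new, unique, unknown or untested is made for them only; others in the source may bear on it.

Measured so far:
Compound 1, `C/C(=N\NC(N)=S)c1sc(C)nc1C`: in a toxicity assay on MCF7 cells (Homo sapiens) for cytotoxicity, read by MTT assay (on this read-out higher numbers stand for weaker inhibition of growth and lower numbers for stronger inhibition of growth), compound 1 gives > 100 ug/mL, which is a limit of the assay rather than a number.
Compound 2, `C/C(=N\Nc1nc(-c2ccc(F)cc2)cs1)c1sc(C)nc1C`: in this assay compound 2 gives > 100 ug/mL, again a limit of the assay and not a number.

Going by the values given here, compound 2 therefore stands only at a limit in this assay, and the one other value shown for comparison is a limit as well; both sit at the limit of > 100 ug/mL in this assay, at which 2 of the 2 values shown sit. Nothing in these two results separates compound 2 from compound 1, and no ordering between them can be read from the numbers.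

The step from compound 2 to compound 3, `C/C(=N\Nc1nc(-c2ccc(C)cc2)cs1)c1sc(C)nc1C`, is a small one: methyl in place of fluoro on an aromatic carbon. Among the compounds with values here, with both anchors sitting at the same limit, there is no measured step on which to base a direction, and no shift beyond the usual scatter is expected in this assay. Compound 3 is estimated in this assay at 150 ug/mL, with a range from 60 ug/mL to 400 ug/mL, which corresponds to an expected step that the limit leaves unreadable from compound 2 to compound 3. Most likely compound 3 will again be reported only as a limit, as compound 2 was at > 100 ug/mL.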

Compound 3, concentration for 50% growth inhibition: > 100 ug/mL
Compound 3 ended at the assay's limit; the forecaster's own chance of this, stated with the estimate: 80%; the middle value lies beyond the limit too.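

In this assay compound 3 gives > 100 ug/mL as a limit of the assay and not a number. Going by these compounds alone, no step from compound 2 to compound 3 can be read, since every value shown stands at the same limit: the limit of > 100 ug/mL in this assay, at which 3 of the 3 values shown sit. The compounds shown leave open whether any change to the shared core brings growth inhibition within the readable range of this read-out.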